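The source may report more compounds than this note shows. Statements on the series, on what has been measured and on what is new or still open speak of the compounds shown alone.

Three compounds share one core and differ only in the group attached to an aromatic carbon of the five-membered ring that carries the amino group. Compound 1 `COc1cc(C(=O)c2sc(-c3cccs3)cc2N)cc(OC)c1OC` bears thiophen-2-yl there, compound 2 `COc1cc(C(=O)c2sc(-c3ccc(C(F)(F)F)cc3)cc2N)cc(OC)c1OC` bears 4-(trifluoromethyl)phenyl, and compound 3 `CCOc1ccc(-c2cc(N)c(C(=O)c3cc(OC)c(OC)c(OC)c3)s2)cc1` bears 4-ethoxyphenyl. In a functional assay on L1210 cells (Mus musculus) for antiproliferative activity (on this read-out higher numbers stand for weaker inhibition and lower numbers for stronger inhibition), compound 1 gives 9.8 nM, compound 2 gives 370 nM and compound 3 gives 590 nM. Compound 3 therefore has the highest number of the three, although the step of a 1.6-fold higher number from compound 2 to compound 3 (0.20 log units; within the scatter) lies within the scatter, so the two six-membered-ring compounds cannot be ordered; the step of a 60-fold higher number from compound 1 to compound 3 (1.78 log units; beyond the scatter) is large and beyond the scatter.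

Compound 4 `COc1cc(C(=O)c2sc(-c3ccsc3)cc2N)cc(OC)c1OC` is the next compound, carrying (thiophen-3-yl in place of 4-ethoxyphenyl on an aromatic carbon). Within the data shown here, two measured steps bear on this change: a 38-fold higher number from compound 1 to compound 2 (1.58 log units; beyond the scatter) and a 60-fold higher number from compound 1 to compound 3 (1.78 log units; beyond the scatter) both show that exchanging a five-membered sulfur ring for a six-membered carbon ring raised the number substantially. Among the measured compounds shown here, compound 4 reverses that kind of exchange, though with thiophen-3-yl, a group none of the measured compounds holds, so whether it fully matches compound 1 remains open. A large lowering, a 30-fold lower number from compound 3 to compound 4 (1.47 log units; beyond the scatter), is therefore expected. Compound 4 is estimated at 20 nM, with a likely range from 6 nM to 80 nM.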

Compound 4, half-maximal inhibitory concentration: 12 nM
Estimate against measurement, compound 4: 1.7-fold (0.22 log units) above; low and high end bracket the measured number.
By their numbers in this assay, from the lowest: compounds 1 and 4 (each within the scatter of the next); then compounds 2 and 3 (each within the scatter of the next).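

In this assay, the step of a 1.2-fold higher number from compound 1 to compound 4 (0.09 log units; within the scatter) lies within the scatter, so on this evidence it makes no measurable difference whether the thiophene ring is joined to the core through its 2-position or its 3-position. The steps of a 49-fold lower number from compound 3 to compound 4 (1.69 log units; beyond the scatter) and a 31-fold lower number from compound 2 to compound 4 (1.49 log units; beyond the scatter) are both large, so the wide gap first seen with thiophen-2-yl also appears with thiophen-3-yl and does not depend on that one way of attaching the ring. No measurement shown here explains why the two thiophene compounds sit so far from the two substituted phenyl compounds.

The change from 4-ethoxyphenyl or 4-(trifluoromethyl)phenyl to a thiophene swaps the ring and removes the ring's substituent at the same time, so these four compounds cannot separate those two changes. An unsubstituted phenyl group would help to do that, while furan-2-yl or furan-3-yl would test whether the ring sulfur is needed at all.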